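From a 4-bromophenyl to a 2,4-dichlorophenyl group

The source may hold more compounds than are shown below. What is called first, only, known or untested is meant among the compounds shown, and "the series" means these compounds.

Compound 1 `OC[C@H]1O[C@@H](n2cnc3c(NCc4cccc(F)c4)ncnc32)[C@H](O)[C@@H]1O`: 4000 nM
Compound 2 `OC[C@H]1O[C@@H](n2cnc3c(NCc4ccc(F)cc4)ncnc32)[C@H](O)[C@@H]1O`: 1250 nM
Compound 3 `OC[C@H]1O[C@@H](n2cnc3c(NCc4ccc(Br)cc4)ncnc32)[C@H](O)[C@@H]1O`: 20600 nM

In a functional assay on CCRF-CEM cells (Homo sapiens) for antiproliferative activity, with a stated time of 72 h (a lower number here means a stronger inhibitor, a higher number a weaker inhibitor), compound 3 has the highest number of the three measured compounds, which makes it the weakest of them. Compound 4 `OC[C@H]1O[C@@H](n2cnc3c(NCc4ccc(Cl)cc4Cl)ncnc32)[C@H](O)[C@@H]1O` keeps the shared core and carries 2,4-dichlorophenyl in place of 4-bromophenyl on a saturated chain carbon bound to a nitrogen on an aromatic ring. Among the measured compounds shown here, no measured step makes this change, and no compound with chlorine has been measured, so the evidence is indirect. The largest relevant step is a 16-fold higher number from compound 2 to compound 3 (1.22 log units; beyond the scatter). In the same direction runs a 5.2-fold higher number from compound 1 to compound 3 (0.71 log units; beyond the scatter), while a 3.2-fold lower number from compound 1 to compound 2 (0.51 log units; beyond the scatter) separates the two fluorinated compounds. Among these three compounds, changing the halogenated phenyl group shifts the number by modest to large steps. Compound 3 stands at the top of this small range at 20600 nM, so a modest step to a lower number is expected, although a higher number cannot be excluded. The expected change is a 2.6-fold lower number from compound 3 to compound 4 (0.41 log units; beyond the scatter). For compound 4 the estimated value is 8000 nM. The expected range runs from 1500 nM to 40000 nM.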

Compound 4, half-maximal inhibitory concentration: 86700 nM
Beside the measured number, compound 4's estimate is 11-fold (1.03 log units) below it; the whole stated range lies below it.
By their numbers in this assay, from the lowest: compound 2; then compound 1; then compound 3; then compound 4.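

In this assay, the 2,4-dichlorophenyl group takes the series beyond the level of 4-bromophenyl, with a 4.2-fold higher number from compound 3 to compound 4 (0.62 log units; beyond the scatter) making compound 4 the weakest of the four compounds. This shows that the number at this position, on a saturated chain carbon bound to a nitrogen on an aromatic ring, had not reached its upper end with compound 3. The distance from the fluorinated compounds is wider still, at a 69-fold higher number from compound 2 to compound 4 (1.84 log units; beyond the scatter) and a 22-fold higher number from compound 1 to compound 4 (1.34 log units; beyond the scatter) and with the 4-fluorophenyl of compound 2 remaining the strongest of the groups shown, while no evidence is available to explain these rises.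

The change from compound 3 to compound 4 swaps the halogen and alters the number of halogen atoms in a single step, so the compounds shown do not separate these two changes. As far as these compounds go, it also remains open how a phenyl ring with a single chlorine, an unsubstituted phenyl ring, or a ring carrying a methoxy group or an amine would compare.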